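Nitro for methyl on the sulfonyl aryl ring

The source may hold more compounds than are shown below. What is called first, only, known or untested is meant among the compounds shown, and "the series" means these compounds.

Compound 1 `CC(=O)c1ccc(NC(=O)C(CC(C)C)N(C(=O)c2ccccc2)S(=O)(=O)c2ccc(C)cc2)cc1` and compound 2 `CC(=O)c1ccc(NC(=O)C(C(C)C)N(C(=O)c2ccccc2)S(=O)(=O)c2ccc(C)cc2)cc1` share one core and differ only at the saturated chain carbon bound to an amide-type nitrogen and a carbonyl carbon. In a functional assay for inhibition, read by spectrophotometry, with a stated time of 20 min, tested at 2 mg/mL (on this read-out higher numbers stand for a stronger effect at the one concentration tested and lower numbers for a weaker effect), compound 1 gives 58.1%. In this assay, for the measured compounds named here, compound 2 gives 22.7%, the lowest of the two numbers so far; the one measured step, a number 35.4 percentage points lower from compound 1 to compound 2 (beyond the scatter), runs beyond the scatter. Compound 3 `CC(=O)c1ccc(NC(=O)C(C(C)C)N(C(=O)c2ccccc2)S(=O)(=O)c2ccc([N+](=O)[O-])cc2)cc1` keeps the isopropyl of compound 2 and carries a different change, (nitro in place of methyl on an aromatic carbon), turning the (4-methylphenyl)sulfonyl group into a (4-nitrophenyl)sulfonyl group. Going by the values given here, the one measured step concerns the chain carbon, not the aromatic carbon of this ring, so no measured step bears on the change and nothing tells its direction. With no comparison to lean on, the expectation for compound 3 is a step of a number 2.3 percentage points higher from compound 2 to compound 3 (within the scatter), a change within the scatter. Compound 3 is therefore estimated at 25%, with a range from 5% to 50%; the range is wide because a number 35.4 percentage points lower from compound 1 to compound 2 (beyond the scatter) shows that one change at a single place in this core can move the number far.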

Compound 3, a percentage reported as inhibition, at one concentration (the size of the read-out at that concentration, not a potency): 29.8%
For compound 3 the middle estimate is 4.8 percentage points below the measured one; the range from low to high includes it.
By their numbers in this assay, from the lowest: compounds 2 and 3 (each within the scatter of the next); then compound 1.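

With the isopropyl held fixed, nitro in place of methyl on the aromatic carbon para to a large group gives, in this assay, a number 7.1 percentage points higher from compound 2 to compound 3 (within the scatter), so at this place three heavy atoms and two hydrogen-bond acceptors can enter for a single carbon without a difference that can be separated from the usual scatter. For the compounds shown here, this is the first reading at the sulfonyl aryl ring, and it stands apart from the step at the saturated chain carbon, a number 35.4 percentage points lower from compound 1 to compound 2 (beyond the scatter), the only step so far that runs beyond the scatter; the (4-nitrophenyl)sulfonyl group and the (4-methylphenyl)sulfonyl group are thus not told apart on this isopropyl core by this read-out. Nothing measured on these compounds bears on why the two groups read alike.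

Open, from the compounds shown here alone, is whether the same swap reads alike on the isobutyl core of compound 1, where the number stands higher and any difference might show more clearly. Also open, going by these compounds, is how an amine or a carboxylic acid would read at this aromatic carbon, and how a longer chain would read at the saturated chain carbon.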